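The source may report more compounds than this note shows. Statements on the series, on what has been measured and on what is new or still open speak of the compounds shown alone.

Compound 1 `CCOc1cc(OC)ccc1C[S+]([O-])c1ncccc1C(=O)Nc1ccncc1`: 0.71 h
Compound 2 `COc1cc(OC)c(OC)cc1C[S+]([O-])c1ncccc1C(=O)Nc1ccncc1`: 0.14 h
Compound 3 `COc1cccc(OC)c1C[S+]([O-])c1ncccc1C(=O)Nc1ccncc1`: 38.5 h

In an ADME assay (on this read-out lower numbers stand for a shorter-lived compound and higher numbers for a longer-lived compound), compound 1 gives 0.71 h, the second highest of the three numbers. It sits far closer to compound 2 than to compound 3. Compound 4 `COCOCCOc1cc(OC)ccc1C[S+]([O-])c1ncccc1C(=O)Nc1ccncc1` is not yet measured. It differs from compound 1 by methoxymethoxy in place of hydrogen on a saturated chain carbon, two bonds along the chain from an oxygen on an aromatic ring, which turns ethoxy into 2-(methoxymethoxy)ethoxy. Within the data shown here, no measured pair differs in one place, so the series offers no direct precedent for this change. The wide spread of the three values argues for a broad range. In this assay a small step toward a shorter-lived compound is expected, not clearly beyond the scatter. The expected change is a 1.8-fold lower number from compound 1 to compound 4 (0.25 log units; within the scatter). The estimate for compound 4 is 0.4 h, with an expected range of 0.1 h to 1.5 h.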

Compound 4, half-life: 2.75 h
For compound 4 the middle estimate is 6.9-fold (0.84 log units) below the measured one; measured number above the stated range.
By their numbers in this assay, from the lowest: compound 2; then compound 1; then compound 4; then compound 3.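

In this assay, among these compounds, methoxymethoxy in place of hydrogen on a saturated chain carbon, two bonds along the chain from an oxygen on an aromatic ring, gives a 3.9-fold higher number from compound 1 to compound 4 (0.59 log units; beyond the scatter), the first one-place step. On this single pair, turning ethoxy into 2-(methoxymethoxy)ethoxy yields a longer-lived compound, so this position accepts a substantial extension. No available data explain the step. Going by these compounds, whether a plain butoxy chain, 2-methoxyethoxy or a terminal amine at this position would shift the number the same way remains open.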